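Swapping methyl for phenyl on the ring nitrogen: a repeat test

This account rests on a few compounds, and the source may have more. Where it says the series, first, only, none or still open, it means among the compounds named here.

Measured compounds:
compound 1, `CN1C(=O)C(c2ccccc2)CC(c2ccccc2)C1=O`: 69.1%
compound 2, `O=C1C(c2ccccc2)CC(c2ccccc2)C(=O)N1c1ccccc1`: 38.3%
compound 3, `CN1C(=O)C(c2ccccc2Cl)CC(c2ccccc2Cl)C1=O`: 61.7%

All three were tested in a functional assay on the whole organism (strain Swiss albino) for inhibition, with Mus musculus as the target, in the maximal electroshock model, with a stated time of 2 h, at a dose of 25 mg/kg by the intraperitoneal route; on this read-out lower numbers stand for less inhibition and higher numbers for more inhibition at the one dose given (going by the name of the read-out). Compound 1 and compound 2 share a core and differ in one place: phenyl in place of methyl on an amide-type nitrogen in a ring. That single swap produced a clear drop, a number 30.8 percentage points lower from compound 1 to compound 2 (beyond the scatter), a large step well beyond the usual scatter of this assay.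

Compound 3 carries the same methyl on the ring nitrogen as compound 1, but its core differs from that of compound 1; the difference between the two cores is not broken down here. In this assay compound 3 gives 61.7%, which lies within the usual scatter of the value of compound 1, so nothing can be said about an order between those two; compound 3 does stand above compound 2 by more than the scatter.

Compound 4, `O=C1C(c2ccccc2Cl)CC(c2ccccc2Cl)C(=O)N1c1ccccc1`, has not yet been measured. It relates to compound 3 as compound 2 relates to compound 1: phenyl in place of methyl on an amide-type nitrogen in a ring. The two places are not identical word for word, since here the two ring atoms each bear a 2-chlorophenyl group rather than a phenyl group, so this is the same kind of change rather than the same change. Because the earlier swap gave a number 30.8 percentage points lower from compound 1 to compound 2 (beyond the scatter), a step of similar size is expected here, namely a number 30.7 percentage points lower from compound 3 to compound 4 (beyond the scatter). On that basis compound 4 is expected to give 31% in this assay, with a plausible range from 15% to 50%.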

Compound 4, a percentage reported as inhibition, in the whole organism at one dose (the size of the read-out at that dose, not a potency): 40.6%
Compound 4: the middle estimate sits 9.6 percentage points below what was measured; low and high end bracket the measured number.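

Phenyl in place of methyl on the ring nitrogen again gives a number 21.1 percentage points lower from compound 3 to compound 4 (beyond the scatter) in this assay and so the loss seen on the core of compound 1 also appears on the core of compound 3. Set side by side, the two steps point the same way and are no further apart than repeated measurements of such steps would be: the same change on two cores in this assay, a number 30.8 percentage points lower (beyond the scatter) from compound 1 to compound 2 and a number 21.1 percentage points lower (beyond the scatter) from compound 3 to compound 4, 9.7 percentage points apart, within the scatter of two such steps. Among these compounds, this supports carrying the change from one of these cores to the other as a drop of similar size, but it rests on only two pairs tested at a single dose, so it does not show that the size of the step depends on the core, nor that the same step would appear on any further core.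

The compounds shown leave open what other groups on the ring nitrogen would do, such as an ethyl group, a benzyl group or the plain amide hydrogen, as only methyl and phenyl stand there. Also open, as far as these compounds go, is whether the step would hold if the two ring atoms that bear phenyl or 2-chlorophenyl groups carried something else, such as a methoxyphenyl group or a chain ending in an amine.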